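The compounds below may be only part of what the source reports. "The series", "measured", "known", "first", "only" and "open" are said of these compounds alone.

Working notes on the series. Compound 3 `O=C1OCCN1C(=O)c1ccc(Oc2cccc(Cl)c2)cc1` stands highest of the two numbers in an assay on HEK293 cells for inhibition of N-acylethanolamine-hydrolyzing acid amidase (Rattus norvegicus), read by LC-MS, with a stated time of 30 min (a higher number here means a weaker inhibitor, a lower number a stronger inhibitor), giving 7740 nM, whereas compound 1 `O=C(CCCCCc1cccc(I)c1)N1CCOC1=O` gives 3120 nM in this assay. Compound 2 `O=C(O)c1cccc(CCCCCC(=O)N2CCOC2=O)c1` reaches only a limit in this assay, reported as > 20000 nM. Within the data shown here, the one measured step, an at least 6.4-fold higher number from compound 1 to compound 2 (0.80 log units; beyond the scatter), rests on the limit of > 20000 nM in this assay, at which 1 of the 3 values shown sits, and concerns a change at a different place from the one considered next.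

Compound 4 `Cc1ccc(Oc2ccc(C(=O)N3CCOC3=O)cc2)cc1` differs from compound 3 by 4-methylphenyl in place of 3-chlorophenyl on an oxygen on an aromatic ring. No measured step bears on an exchange of this kind, so no direction can be drawn from the numbers shown. The step from compound 3 to compound 4 is therefore expected to be a 1.2-fold lower number from compound 3 to compound 4 (0.08 log units; within the scatter), within the scatter. Compound 4 is estimated at 6500 nM in this assay, with a range from 2500 nM to 17000 nM.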

Compound 4, half-maximal inhibitory concentration: 6400 nM
Beside the measured number, compound 4's estimate is 1.0-fold (0.01 log units) above it; the range from low to high includes it.
By their numbers in this assay, from the lowest: compound 1; then compounds 4 and 3 (each within the scatter of the next). At a limit, above all of these: compound 2.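

In this assay the change to 4-methylphenyl in place of 3-chlorophenyl on an oxygen on an aromatic ring gives a 1.2-fold lower number from compound 3 to compound 4 (0.08 log units; within the scatter) and so does not separate the two groups. This is the only step shown at this place, and it shows that this exchange leaves the number within the scatter, which the earlier compounds could not show. Nothing shown gives a reason for this result.

Open, as far as these compounds go, is whether an amine or a carboxylic acid on this ring would move the number beyond the scatter. Also open, from the compounds shown here alone, is how a longer chain in place of 4-methylphenyl on this oxygen would read.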